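A Pyrazole for a Pyridine on an Antiproliferative Core

The source may report more compounds than this note shows. Statements on the series, on what has been measured and on what is new or still open speak of the compounds shown alone.

Compound 1 `N#Cc1ccc(N2CCCc3c(-c4cccnc4)cccc32)cc1C(F)(F)F`: 7970 nM in a functional assay on PC-3 cells (Homo sapiens) for antiproliferative activity, read by CCK-8 assay, with a stated time of 6 days; a higher number here means a weaker inhibitor, a lower number a stronger inhibitor
Compound 2 `CCN(c1ccc(C#N)c(Cl)c1)c1cc(-c2cncnc2)ccc1C`: the assay limit > 30000 nM
Compound 3 `CCN(c1ccc(C#N)c(Cl)c1)c1cc(-n2cccn2)ccc1C`: 15700 nM

In this assay compound 1 carries one of the two actual numbers shown; the other belongs to compound 3, and the two lie within the usual scatter of each other. The value of compound 2 is a limit, not a number.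

Compound 4 `Cn1nccc1-c1cccc2c1CCCN2c1ccc(C#N)c(C(F)(F)F)c1` differs from compound 1 by 1-methyl-1H-pyrazol-5-yl in place of pyridin-3-yl on an aromatic carbon. Among the compounds with values here, the only measured step that resembles it is an at least 1.9-fold lower number from compound 2 to compound 3 (0.28 log units; that floor lies within the scatter), where a five-membered ring also replaced a six-membered one, though on a different core; it stayed within the scatter, and one end of it rests on the limit (the limit of > 30000 nM in this assay, at which 1 of the 3 values shown sits). So no step beyond the scatter is expected: a 1.1-fold lower number from compound 1 to compound 4 (0.06 log units; within the scatter). Compound 4 is therefore estimated at 7000 nM, with a range of 2500 nM to 20000 nM.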

Compound 4, half-maximal inhibitory concentration: 9800 nM
For compound 4 the middle estimate is 1.4-fold (0.15 log units) below the measured one, within the range that was stated.
By their numbers in this assay, from the lowest: compounds 1, 4 and 3 (each within the scatter of the next). At a limit, above all of these: compound 2.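

In this assay, swapping the ring on this aromatic carbon of the shared core gives a 1.2-fold higher number from compound 1 to compound 4 (0.09 log units; within the scatter). Both ends of this step are actual numbers, so a five-membered ring can replace a six-membered one here with no detectable change, and that reading rests on no limit. Compound 2, from the earlier step, has a limit and not a number: the limit of > 30000 nM in this assay, at which 1 of the 4 values shown sits.

Going by these compounds, whether any group at this position would move the number beyond the scatter stays open. A simple amine, a carboxylic acid or a plain phenyl ring could test this.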